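Swapping the fluoroindazole of compound 1 for a pyridine-fused ring

This account rests on a few compounds, and the source may have more. Where it says the series, first, only, none or still open, it means among the compounds named here.

Three urea compounds built on a shared core have been measured in a functional assay on MDA-MB-231 cells (Homo sapiens) for cytotoxicity, read by MTT assay, with a stated time of 72 h; a lower number here means a stronger inhibitor, a higher number a weaker inhibitor. Compound 1 `O=C(Nc1ccc(-n2ncc3c(F)cccc32)cc1)Nc1ccc(Cl)c(C(F)(F)F)c1` gives 3100 nM, compound 2 `O=C(Nc1ccc(-n2ncc3c(C(F)(F)F)cccc32)cc1)Nc1ccc(C(F)(F)F)cc1` gives 2000 nM and compound 3 `O=C(Nc1ccc(-n2ncc3c(Cl)cccc32)cc1)Nc1ccc(C(F)(F)F)cc1` gives 2700 nM. Compound 1 has the highest of the three numbers, but its distance to compound 3 and to compound 2 lies within the scatter, so no order among them can be claimed. Among the measured compounds shown here, the only single-point step among them, a 1.4-fold higher number from compound 2 to compound 3 (0.13 log units; within the scatter), is also within the scatter.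

Compound 4 `O=C(Nc1ccc(-n2ncc3cccnc32)cc1)Nc1ccc(Cl)c(C(F)(F)F)c1` differs from compound 1 in one place: a group of 9 heavy atoms (6 carbon, 3 nitrogen; one five-membered aromatic ring with 2 hetero atoms, one six-membered aromatic ring with 1 hetero atom) in place of a group of 10 heavy atoms (7 carbon, 2 nitrogen, 1 fluorine; one five-membered aromatic ring with 2 hetero atoms, one six-membered aromatic ring of carbon only), on an aromatic carbon, on an aromatic carbon of a six-membered aromatic ring of carbon only, para to a large group. For the measured compounds named here, no measured pair shows this kind of exchange, and the one step that exists concerns a different position and was small. The expectation is therefore a step of no clear direction, a 1.0-fold lower number from compound 1 to compound 4 (0.01 log units; within the scatter), staying within the scatter. Compound 4 is estimated at 3000 nM, within 1200 nM to 8000 nM.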

Compound 4, half-maximal inhibitory concentration: > 32000 nM
Compound 4 gave a limit, no number (the forecaster's own chance of this, stated with the estimate: 10%); at least 10-fold (1.02 log units) between middle value and limit.
By their numbers in this assay, from the lowest: compounds 2, 3 and 1 (each within the scatter of the next). At a limit, above all of these: compound 4.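

The earlier steps shown here all stayed within the scatter, so they gave no sign that any part of these ureas mattered much. The exchange on this aromatic carbon, para to a large group, gives an at least 10-fold higher number from compound 1 to compound 4 (1.01 log units; beyond the scatter), which shows that in this assay this position does not tolerate every change, at least in this one pair. Compound 4 stands at a limit of the assay and not at a number: the limit of > 32000 nM in this assay, at which 1 of the 4 values shown sits.

The loss of the fluorine and the new nitrogen in the six-membered ring arrive together, so this pair cannot say which of them matters, or how large the full step is. Also open, going by these compounds, is whether a methoxy group or an amine on that six-membered ring would keep the cytotoxicity of compound 1.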